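Swapping a sulfonyl group for a thiophene arm

The compounds below may be only part of what the source reports. "The series", "measured", "known", "first", "only" and "open" are said of these compounds alone.

Three compounds have been measured in an assay on CHO cells for displacement of a labelled ligand from 5-hydroxytryptamine receptor 1B (Homo sapiens); a lower number here means a stronger inhibitor, a higher number a weaker inhibitor:
Compound 1, `O[C@H]1Cc2ccccc2C1NC1CCN(CCCc2c[nH]c3ccc(-n4cnnc4)cc23)CC1`, gives 300 nM.
Compound 2, `CC(C)=CCCN(C)C1CCN(CCCc2c[nH]c3ccc(-n4cnnc4)cc23)CC1`, gives 24 nM.
Compound 3, `CN(C1CCN(CCCc2c[nH]c3ccc(-n4cnnc4)cc23)CC1)S(=O)(=O)c1ccccc1`, gives 10 nM.

All three share the same core and differ only in the group on the amine nitrogen attached to a saturated ring carbon. Compound 3 has the lowest number of the three, so it is the strongest inhibitor seen so far: the change a 2.4-fold lower number from compound 2 to compound 3 (0.38 log units; beyond the scatter) is modest, while a 30-fold lower number from compound 1 to compound 3 (1.48 log units; beyond the scatter) and a 13-fold lower number from compound 1 to compound 2 (1.10 log units; beyond the scatter) are both large.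

Compound 4, `CN(Cc1cccs1)C1CCN(CCCc2c[nH]c3ccc(-n4cnnc4)cc23)CC1`, is not yet measured. It is derived from compound 3 by the change ((thiophen-2-yl)methyl in place of phenylsulfonyl on an amine nitrogen). Among the measured compounds shown here, no measured step covers exactly this swap. The closest comparison is compound 2, whose amine nitrogen carries a plain carbon chain rather than a sulfonyl, and which sits only modestly behind compound 3 in this assay. The new group again joins the nitrogen through a carbon, so compound 4 is expected to land near compound 2, with a small loss compared with compound 3 that may stay within the usual scatter. The step of a 2.0-fold higher number from compound 3 to compound 4 (0.30 log units; within the scatter) is therefore the estimate, giving compound 4 an expected value of 20 nM, in the range 6 nM to 60 nM.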

Compound 4, half-maximal inhibitory concentration: 140 nM
For compound 4 the middle estimate is 7.0-fold (0.85 log units) below the measured one, and the stated range ends below it.
By their numbers in this assay, from the lowest: compound 3; then compound 2; then compound 4; then compound 1.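

In this assay, the group on this amine nitrogen can move the number a long way even when an aromatic ring stays in place: both groups carry one, yet the swap from phenylsulfonyl to (thiophen-2-yl)methyl gives a 14-fold higher number from compound 3 to compound 4 (1.15 log units; beyond the scatter) in a single change. Joining the group to the nitrogen through a carbon does not by itself fix the result either, since the two carbon-joined arms also part, with a 5.8-fold higher number from compound 2 to compound 4 (0.77 log units; beyond the scatter) when thiophen-2-yl replaces 3-methylbut-2-en-1-yl on the saturated chain carbon. The thiophene arm still does better than the arm of compound 1, but only by a modest margin, with a 2.1-fold lower number from compound 1 to compound 4 (0.33 log units; beyond the scatter) as the step read in the other direction.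

Why the thiophene arm falls so far remains unexplained, as nothing available bears on it. A benzyl group on the same nitrogen would keep the phenyl ring and change only the link, while a thiophen-2-ylsulfonyl group would keep the sulfonyl and change only the ring, and the compounds shown cannot yet say which part of the swap carries the loss.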